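The compounds below may be only part of what the source reports. "The series", "measured", "known", "first", "only" and "open" are said of these compounds alone.

Compound 1 `COc1cc(C2CC(c3ccc(Br)cc3)=NN2C(C)=O)ccc1OCc1cn(Cc2ccc([N+](=O)[O-])cc2)nn1` holds the smaller of the two numbers in hand, though the gap to compound 2 is within the usual scatter. In a functional assay on THP-1 cells (Homo sapiens) for inhibition, read by sulforhodamine B assay, tested at 10 uM (on this read-out lower numbers stand for less inhibition of growth and higher numbers for more inhibition of growth at the one concentration tested), compound 1 gives 1%. Compound 2 `COc1ccc(C2CC(c3ccc(OCc4cn(Cc5ccc([N+](=O)[O-])cc5)nn4)cc3)=NN2C(C)=O)cc1OC` in this assay gives 8%, so neither value stands apart from the other. Compound 3 `COc1ccc(C2=NN(C(C)=O)C(c3ccc(OCc4cn(Cc5ccc([N+](=O)[O-])cc5)nn4)c(OC)c3)C2)cc1` differs from compound 1 in one place: methoxy in place of bromo on an aromatic carbon. With both measured values this low, no step beyond the scatter is expected, and the expected step from a number 4 percentage points higher from compound 1 to compound 3 (within the scatter) is essentially flat. Compound 3 is therefore estimated at 5% in this assay, with a range from -8% to 20%.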

Compound 3, percent growth inhibition at one concentration: 8%
Estimate against measurement, compound 3: 3 percentage points below, and the stated range covers the measured number.
By their numbers in this assay, from the lowest: compounds 1, 2 and 3 (each within the scatter of the next).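

Methoxy in place of bromo on this aromatic carbon, para to a large group, gives a number 7 percentage points higher from compound 1 to compound 3 (within the scatter) in this assay. This first comparison at a single place shows that going from 4-bromophenyl to 4-methoxyphenyl on the core of compound 1 does not separate the two compounds on this read-out. Nothing available gives a reason for this result. The compounds shown leave open whether an amine or a carboxylic acid at this place would stand apart from these numbers, and whether a longer chain on the oxygen of the methoxy would do so.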